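The source may hold more compounds than are shown below. What is called first, only, known or untested is meant among the compounds shown, and "the series" means these compounds.

Measured in a functional assay on MCF7 cells (Homo sapiens) for cytotoxicity, read by MTT assay, with a stated time of 72 h; a lower number here means a stronger inhibitor, a higher number a weaker inhibitor:
Compound 1 `N[C@H]1CC[C@H](Nc2c(C(=O)NCc3ccc(F)cc3)nc(N3CCCCS3(=O)=O)c3cccnc23)CC1`: 13000 nM
Compound 2 `CS(=O)(=O)Oc1c(C(=O)NCc2ccc(F)cc2)nc(Br)c2cccnc12`: "not determined" (no result reported)

Compound 2 has no place on this scale. Its entry reads "not determined" (no result reported), so there is no number to serve as a starting point. Compound 3 `NCCCNc1c(C(=O)NCc2ccc(F)cc2)nc(Br)c2cccnc12` is still waiting for its measurement. The structural step is (3-aminopropyl)amino in place of (methylsulfonyl)oxy on an aromatic carbon, para to a bromo group.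

Among the measured compounds shown here, no measured pair shows what a change like this does in this assay, so the size of the step itself cannot be read from the data. For the measured compounds named here, the only available anchor is compound 1, which gives 13000 nM and also has an amino-bearing group attached through a nitrogen to the core. However, compound 1 has a different amine group and lacks the bromo group, so it is only a loose guide. Compound 3 is therefore expected to be a weak inhibitor, close to compound 1 or moderately stronger. The estimated value for compound 3 is 6000 nM, with an expected range of 1500 nM to 25000 nM.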

Compound 3, half-maximal inhibitory concentration: 6000 nM
Estimate against measurement, compound 3: no gap at the digits printed, within the range that was stated.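

In this assay compound 3 gives 6000 nM, but compound 2 has no number on this scale, so no step can be read between the two. Nothing shown here offers an explanation for the value of compound 3. The compounds shown leave open how replacing (methylsulfonyl)oxy with (3-aminopropyl)amino changes the read-out.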